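A few compounds are considered here, and "the series" means these few. Any claim that something is new, unique, unknown or untested is made for them only; others in the source may bear on it.

The study centres on a physicochemical assay for solubility, in phosphate buffer, measured as kinetic solubility, with a stated time of 1 h, at pH 7.4; on this read-out lower numbers stand for lower solubility and higher numbers for higher solubility. Three compounds carry numbers there. Compound 1 `O=C(O)Cc1ccccc1-c1cccc(NC(=O)OCc2ccccc2)c1` gives 287 ug/mL in this assay. Compound 2 `O=C1CN(Cc2ccc(-c3ccc(C4(C(=O)O)CC4)cc3)cc2)C(=O)N1c1ccccc1` gives 195 ug/mL, and compound 3 `O=C(O)Cc1ccc(-c2ccc(CN3CC(=O)N(C4CCCCC4)C3=O)cc2)cc1` gives 186 ug/mL. Compound 1 thus holds the highest of the three numbers, yet its gap to compound 2 and its gap to compound 3 both fall within the usual scatter of this assay, so the three compounds stand level for practical purposes and no order among them can be claimed. Within the data shown here, none of these three differs from another in a single place, so no one-point step between measured compounds can be read off from them.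

The account follows the move from compound 1 to compound 4 `O=C(Nc1cccc(-c2ccccc2)c1)OCc1ccccc1`, which has not yet been measured in this assay. The change is hydrogen in place of carboxymethyl on an aromatic carbon. Among the measured compounds shown here, no pair among the measured compounds shows this change, so the expectation has to rest on the structural change itself and on the numbers of compound 1. The step from compound 1 to compound 4 is expected to run downward and to exceed the scatter, at an estimated 19-fold lower number from compound 1 to compound 4 (1.28 log units; beyond the scatter). Compound 4 is accordingly estimated at 15 ug/mL in this assay, with a range from 3 ug/mL to 60 ug/mL.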

Compound 4, solubility: 5 ug/mL
Estimate against measurement, compound 4: 3.0-fold (0.48 log units) above, within the range that was stated.
By their numbers in this assay, from the lowest: compound 4; then compounds 3, 2 and 1 (each within the scatter of the next).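

Among these compounds, the first step in this assay between compounds that differ in one place is a large one, a 57-fold lower number from compound 1 to compound 4 (1.76 log units; beyond the scatter), and it lies beyond the scatter. It shows that, on this aromatic carbon of a six-membered aromatic ring of carbon only, ortho to a large group, hydrogen and carboxymethyl do not stand level on this read-out, with hydrogen on the low side. The earlier compounds could not show this, as none of them differs from another in a single place, and nothing given here accounts for the size of the step.

The compounds shown leave open whether a step of this size belongs to carboxymethyl in particular or would also appear with another group at this place, such as a carboxylic acid set directly on the ring, an aminomethyl group or a longer chain such as carboxyethyl. They also leave open whether the same change would run the same way and as far on another core, as this single pair is the only one of its kind here.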